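Swapping Methyl for Fluoro in a Cell Toxicity Series

The source may report more compounds than this note shows. Statements on the series, on what has been measured and on what is new or still open speak of the compounds shown alone.

Compound 1 `Cc1ccc(NC(=S)OCCNC(=O)c2cccnc2)cc1` was tested in an ADME assay on H9c2 cells (Rattus norvegicus) for cytotoxicity, read by MTT assay, with a stated time of 48 h (a higher number here means a weaker inhibitor, a lower number a stronger inhibitor), and gave 726000 nM. Compound 2 `Cc1cnc(C(=O)Oc2ccc(C(N)=S)cc2)c[n+]1[O-]` gave 780000 nM in this assay; the two numbers sit within the scatter of one another, so neither compound can be called the weaker or the stronger. Compound 3 `O=C(NCCOC(=S)Nc1ccc(F)cc1)c1cccnc1` is not yet measured; it differs from compound 1 by fluoro in place of methyl on an aromatic carbon. With nothing shown between measured compounds, no step beyond the scatter is expected, and the shift a 1.0-fold lower number from compound 1 to compound 3 (0.02 log units; within the scatter) is an estimate of that. Compound 3 is expected to give 700000 nM in this assay, between 350000 nM and 1400000 nM, because compound 1 gives 726000 nM.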

Compound 3, half-maximal inhibitory concentration: > 800000 nM
Compound 3: a limit, no number; the forecaster's own chance of this, stated with the estimate: 10%; at least 1.1-fold (0.05 log units) between middle value and limit.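

In this assay, compound 3 gives > 800000 nM, which is a limit of the assay and not a number. Fluoro in place of methyl on the aromatic carbon gives the first step at this position, an at least 1.1-fold higher number from compound 1 to compound 3 (0.04 log units; that floor lies within the scatter), so this change shows only a floor and no clear shift. The true size of the step stays hidden, since the reading stops at the top of the assay's range: the limit of > 800000 nM in this assay, at which 1 of the 3 values shown sits.

From the compounds shown here alone, how far compound 3 lies beyond its limit remains open. So does whether an amine or a methoxy group at this position would move the value clearly away from that of compound 1.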